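The source may hold more compounds than are shown below. What is called first, only, known or untested is meant among the compounds shown, and "the series" means these compounds.

Measured compounds in an assay for inhibition of ribosomal protein S6 kinase beta-1 variant D18H,T412E (Homo sapiens), read by a luciferase reporter and chemiluminescence, with a stated time of 3 h; on this read-out higher numbers stand for weaker inhibition and lower numbers for stronger inhibition: compound 1 `CCc1n[nH]c2ncnc(N3CCN(c4cc(Cl)ccc4C)CC3)c12` gives 6 nM; compound 2 `Cc1ccc(Cl)cc1N1CCN(c2ncnc3[nH]nc(C(C)C)c23)CC1` gives 16 nM; compound 3 `CCCc1n[nH]c2ncnc(N3CCN(c4cc(Cl)ccc4C)CC3)c12` gives 6 nM.

Compound 3 stands level with compound 1 at the digits shown, the two together giving the lowest numbers of the three; compound 2 is the furthest, with a 2.7-fold lower number from compound 2 to compound 3 (0.43 log units; beyond the scatter) read the other way. Within the data shown here, the only step in the measured set that goes beyond the scatter is a 2.7-fold higher number from compound 1 to compound 2 (0.43 log units; beyond the scatter), while no change at the digits printed from compound 1 to compound 3 (within the scatter) sits within it, so lengthening the chain by one carbon leaves the number where it was and branching it raises the number modestly.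

Compound 4 `Cc1ccc(Cl)cc1N1CCN(c2ncnc3[nH]nc(Br)c23)CC1` differs from compound 3 by bromo in place of propyl on an aromatic carbon, on an aromatic carbon of a five-membered aromatic ring with 2 nitrogen, part of a fused or bridged system of two rings. Among the measured compounds shown here, no measured step exchanges an alkyl chain for a halogen at this carbon; the measured steps only show that the size and shape of the alkyl group there move the number modestly or not at all. A bromo group is a single heavy atom in place of a three-carbon chain, so a step of about the size seen between the alkyl variants is expected, with the direction uncertain and a slightly higher number more likely.

Compound 4 is therefore estimated at 10 nM, within 3 nM to 40 nM, an expected step of a 1.7-fold higher number from compound 3 to compound 4 (0.22 log units; within the scatter).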

Compound 4, half-maximal inhibitory concentration: 7 nM
Compound 4: the middle estimate sits 1.4-fold (0.15 log units) above what was measured; low and high end bracket the measured number.
By their numbers in this assay, from the lowest: compounds 1, 3 and 4 (each within the scatter of the next); then compound 2.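

In this assay, the alkyl chain is not required at this aromatic carbon of the five-membered aromatic ring: with bromo, 1 heavy atom, in place of propyl, 3 heavy atoms, the result is a 1.2-fold higher number from compound 3 to compound 4 (0.07 log units; within the scatter), and with bromo in place of ethyl it is a 1.2-fold higher number from compound 1 to compound 4 (0.07 log units; within the scatter), so bromo cannot be separated from either unbranched chain in this read-out. Compound 2, with its isopropyl group, stays apart from the other three compounds, and the exchange for bromo gives a 2.3-fold lower number from compound 2 to compound 4 (0.36 log units; beyond the scatter), so a non-alkyl group now joins the unbranched chains on the side of the lower numbers. Nothing available explains why bromo and the unbranched chains read alike.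

The compounds shown leave open whether other groups on this carbon, such as an amine, a carboxylic acid, a chloro group or a longer chain such as butyl, would stay in the same range of numbers. They also leave open whether the match between bromo and the unbranched chains would hold with a change elsewhere, as the rest of the structure is the same in all four compounds.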